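From 2-methoxyphenyl to 3-chloropropyl on the shared core

The compounds below may be only part of what the source reports. "The series", "measured", "known", "first", "only" and "open" are said of these compounds alone.

Values measured in a functional assay on CFPAC-1 cells (Homo sapiens) for antiproliferative activity, read by MTT assay, with a stated time of 72 h (a lower number here means a stronger inhibitor, a higher number a weaker inhibitor), follow
Compound 1 (`O=C1O[C@H]([C@@H](O)Cn2cc(-c3cc(C(F)(F)F)cc(C(F)(F)F)c3)nn2)C(OCc2ccccc2)=C1OCc1ccccc1`) gives 66500 nM
Compound 2 (`CC(C)(C)OC(=O)N1CCN(C(=S)SCc2cn(C[C@H](O)[C@H]3OC(=O)C(OCc4ccccc4)=C3OCc3ccccc3)nn2)CC1`) gives > 100000 nM (a limit)
Compound 3 (`COc1ccccc1-c1cn(C[C@H](O)[C@H]2OC(=O)C(OCc3ccccc3)=C2OCc2ccccc2)nn1`) gives > 100000 nM (a limit)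

Compound 3 stands at > 100000 nM in this assay and this is a limit of the assay, not a number. The set as a whole shows the limit of > 100000 nM in this assay, at which 2 of the 3 values shown sit, and so offers thin guidance. Compound 4 (`O=C1O[C@H]([C@@H](O)Cn2cc(CCCCl)nn2)C(OCc2ccccc2)=C1OCc1ccccc1`) carries 3-chloropropyl in place of 2-methoxyphenyl on an aromatic carbon. Only compound 1, at 66500 nM and thus a true number, shows measurable activity in this set. A small step toward stronger inhibition is expected (an at least 1.6-fold lower number from compound 3 to compound 4 (0.22 log units; that floor lies within the scatter)) in this assay and a reading at the limit again remains possible. For compound 4 the estimate is 60000 nM with an expected range from 15000 nM to 150000 nM as the measurement is awaited.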

Compound 4, half-maximal inhibitory concentration: 58800 nM
Estimate against measurement, compound 4: 1.0-fold (0.01 log units) above, and the stated range covers the measured number.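

In this assay, compound 4 shows that a group without a ring, 3-chloropropyl, can stand on this aromatic carbon and still give a true number. The step of an at least 1.7-fold lower number from compound 3 to compound 4 (0.23 log units; that floor lies within the scatter) is only a floor and does not establish a change beyond the scatter. Its true size stays unknown because compound 3 reads only as a limit: the limit of > 100000 nM in this assay, at which 2 of the 4 values shown sit.

As far as these compounds go, whether a shorter alkyl chain, a longer chain ending in an amine, or a carboxylic acid at this position would shift the reading stays open. So does the part played by the chlorine atom of compound 4.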